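Alkoxy change in a two-compound series: working notes

The source may hold more compounds than are shown below. What is called first, only, known or untested is meant among the compounds shown, and "the series" means these compounds.

Measured so far:
compound 1 `C=C(C)C(=O)Nc1cc2c(N3CCc4ccccc43)ncnc2cc1OC` — 4830 nM
compound 2 `CCC/C=C/C(=O)Nc1cc2c(N3CCc4ccccc43)ncnc2cc1OC` — 4240 nM

In a functional assay on PC-3 cells (Homo sapiens) for antiproliferative activity, read by MTT assay, with a stated time of 72 h (on this read-out higher numbers stand for weaker inhibition and lower numbers for stronger inhibition), compound 1 gives 4830 nM and stands highest of the two numbers; compound 2 gives 4240 nM. For the measured compounds named here, the single measured step, a 1.1-fold lower number from compound 1 to compound 2 (0.06 log units; within the scatter), lies within the scatter.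

Compound 3 `C=C(C)C(=O)Nc1cc2c(N3CCc4ccccc43)ncnc2cc1O[C@@H]1CCOC1` differs from compound 1 by oxolan-3-yl in place of methyl on an oxygen on an aromatic ring. Going by the values given here, no measured step touches the oxygen on the aromatic ring; the only step, a 1.1-fold lower number from compound 1 to compound 2 (0.06 log units; within the scatter), changes the group on the carbonyl carbon and is within the scatter. For compound 3 no step beyond the scatter is therefore expected, a 1.2-fold lower number from compound 1 to compound 3 (0.08 log units; within the scatter). From the compounds shown here alone, the estimate for compound 3 is 4000 nM, with a range of 1000 nM to 15000 nM, kept wide since this position is untested.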

Compound 3, half-maximal inhibitory concentration: 4910 nM
Beside the measured number, compound 3's estimate is 1.2-fold (0.09 log units) below it, and the stated range covers the measured number.
By their numbers in this assay, from the lowest: compounds 2, 1 and 3 (each within the scatter of the next).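

At the oxygen on an aromatic ring, the change from methoxy to (oxolan-3-yl)oxy now has a measured step in this assay (a 1.0-fold higher number from compound 1 to compound 3 (0.01 log units; within the scatter)). With the 1-methylethenyl amide held constant, this position therefore takes a five-membered non-aromatic ring with one more hydrogen-bond acceptor and no step beyond the scatter. No evidence on hand accounts for this result.

Still open, from the compounds shown here alone, is whether an amine or a carboxylic acid on this oxygen would give a step beyond the scatter. Going by these compounds, the other stereoisomer of the oxolan-3-yl group also remains open.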